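The source may hold more compounds than are shown below. What is called first, only, known or untested is meant among the compounds shown, and "the series" means these compounds.

Compound 1 `COc1ccc(-n2nc(C(=O)Nc3ccc(C)cc3)nc2-c2cc(OC)c(OC)c(OC)c2)cc1`: 38%; compound 2 `COc1ccc(-n2nc(C(=O)Nc3cccc(F)c3)nc2-c2cc(OC)c(OC)c(OC)c2)cc1`: 48%.

In a functional assay on the whole organism for inhibition, with Rattus norvegicus as the target, read by paw edema, with stated times of 30 min and 1 h, at a dose of 0.28 mmol/kg by the oral route (on this read-out lower numbers stand for less inhibition and higher numbers for more inhibition at the one dose given (going by the name of the read-out)), compound 1 gives 38%, the lowest of the two numbers shown, though its nearest neighbour compound 2 lies within the scatter (a number 10 percentage points higher from compound 1 to compound 2 (within the scatter)). Compound 3 `COc1ccc(-n2nc(C(=O)Nc3ccccc3)nc2-c2cc(OC)c(OC)c(OC)c2)cc1` differs from compound 1 by hydrogen in place of methyl on an aromatic carbon. Within the data shown here, the one measured step, a number 10 percentage points higher from compound 1 to compound 2 (within the scatter), concerns the same amide-type nitrogen but a different aryl change, and sits within the scatter, so no step beyond the scatter is expected in this assay. Compound 3 is estimated at 42%, between 25% and 60%, an expected step of a number 4 percentage points higher from compound 1 to compound 3 (within the scatter).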

Compound 3, a percentage reported as inhibition, in the whole organism at one dose (the size of the read-out at that dose, not a potency): 45%
Beside the measured number, compound 3's estimate is 3 percentage points below it, and the stated range covers the measured number.
By their numbers in this assay, from the lowest: compounds 1, 3 and 2 (each within the scatter of the next).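

With hydrogen in place of methyl on the aromatic carbon, the unsubstituted phenyl gives a number 7 percentage points higher from compound 1 to compound 3 (within the scatter) in this assay, and hydrogen in place of fluoro gives a number 3 percentage points lower from compound 2 to compound 3 (within the scatter) in the same assay. Phenyl therefore provides a direct reference for both substituted rings, and neither the methyl nor the fluoro separates from hydrogen beyond the scatter. As far as these compounds go, whether a dimethylamino group or a carboxylic acid on this ring would give a step beyond the scatter remains open. So does the effect of changing the methoxy groups on the shared core. No supporting data bear on why these numbers lie so close.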